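One benzyl swap on compound 2

The source may hold more compounds than are shown below. What is called first, only, known or untested is meant among the compounds shown, and "the series" means these compounds.

- compound 1 `COc1ccc(/C=C2\CN(C(=S)SCc3cn(Cc4ccccc4F)nn3)C/C(=C\c3ccc(OC)cc3)C2=O)cc1`: 49900 nM
- compound 2 `Cc1ccc(/C=C2\CN(Cc3cn(Cc4ccc(F)cc4)nn3)C/C(=C\c3ccc(C)cc3)C2=O)cc1`: 57200 nM
- compound 3 `Cc1ccc(/C=C2\CN(C(=S)SCc3cn(Cc4cccc(Cl)c4)nn3)C/C(=C\c3ccc(C)cc3)C2=O)cc1`: 53400 nM

All three values come from a functional assay on 4T1 cells (Mus musculus) for cytotoxicity, read by MTT assay, with a stated time of 24 h; on this read-out higher numbers stand for weaker inhibition and lower numbers for stronger inhibition. Repeated measurements of this kind naturally differ somewhat, and that scatter matters here. Compound 2 gives 57200 nM, a value within the scatter of both other compounds, so these numbers cannot separate the three.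

The next compound to test is compound 4 `Cc1ccc(/C=C2\CN(Cc3cn(Cc4cccc(Cl)c4)nn3)C/C(=C\c3ccc(C)cc3)C2=O)cc1`. It differs from compound 2 in one place: 3-chlorophenyl in place of 4-fluorophenyl on a saturated chain carbon bound to an aromatic nitrogen. Put simply, 3-chlorophenyl stands in place of 4-fluorophenyl on a saturated chain carbon bound to an aromatic nitrogen, which can also be read as 4-fluorobenzyl to 3-chlorobenzyl.

For the measured compounds named here, no pair of measured compounds isolates this change, since compound 1 and compound 3 each differ from compound 2 in more than one place. The closest hint is compound 3, which already carries the 3-chlorobenzyl group and gives 53400 nM, within the scatter of compound 2. No change beyond the scatter is therefore expected in this assay, and the estimated 1.1-fold lower number from compound 2 to compound 4 (0.06 log units; within the scatter) reflects that. The expected value for compound 4 is 50000 nM, with an estimated range from 30000 nM to 80000 nM.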

Compound 4, half-maximal inhibitory concentration: 29300 nM
Estimate against measurement, compound 4: 1.7-fold (0.23 log units) above, and the stated range ends above it.
By their numbers in this assay, from the lowest: compounds 4, 1, 3 and 2 (each within the scatter of the next).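

The swap of 4-fluorobenzyl to 3-chlorobenzyl can now be read on its own in this assay, and it gives a 2.0-fold lower number from compound 2 to compound 4 (0.29 log units; within the scatter). Because that step stays within the scatter, the two values cannot be told apart, so this place on the saturated chain carbon bound to an aromatic nitrogen accepts either group with no measurable change, even though the halogen and its ring position both differ while the heavy-atom count stays the same. Nothing measured here bears on what lies behind the step.

Larger changes at this place remain open: an amine or a carboxylic acid on the phenyl ring, or a longer chain in place of the benzyl group, might or might not move the number beyond the scatter. It is also open whether the same swap would give a similar step on the different linker carried by compound 1 and compound 3, as no pair shown tests it there.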